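Extending the aminomethyl arm of a fucosidase inhibitor

The source may report more compounds than this note shows. Statements on the series, on what has been measured and on what is new or still open speak of the compounds shown alone.

Compound 2 `CC1NC(CN)(CO)C(O)C(O)C1O` stands as the weaker of the two measured compounds: in an assay on isolated protein for inhibition of tissue alpha-L-fucosidase (Homo sapiens) (on this read-out higher numbers stand for weaker inhibition and lower numbers for stronger inhibition), compound 2 gives 206 nM, while compound 1 `CC1NC(C#N)(CO)C(O)C(O)C1O` gives 75 nM. For the measured compounds named here, the only measured step, a 2.7-fold higher number from compound 1 to compound 2 (0.44 log units; beyond the scatter), shows that exchanging the cyano for an aminomethyl on the saturated ring carbon raises the number. Compound 3 `CC1NC(CO)(CNC(=O)CN)C(O)C(O)C1O` carries that arm one stage further: (aminomethyl)carbonyl in place of hydrogen on an amine nitrogen, so the amino becomes a ((aminomethyl)carbonyl)amino. Going by the values given here, no measured step touches this nitrogen, so the expectation rests on the step from compound 1 to compound 2 alone, which points to a modest rise when the arm grows. A further modest rise is therefore expected, a 2.9-fold higher number from compound 2 to compound 3 (0.46 log units; beyond the scatter). Compound 3 is estimated at 600 nM in this assay, with a likely range from 150 nM to 2500 nM.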

Compound 3, half-maximal inhibitory concentration: 50 nM
Compound 3: the middle estimate sits 12-fold (1.08 log units) above what was measured; measured number outside the range, below it.
By their numbers in this assay, from the lowest: compounds 3 and 1 (each within the scatter of the next); then compound 2.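

Putting (aminomethyl)carbonyl on the amine nitrogen of the arm lowers the number rather than raising it, with a 4.1-fold lower number from compound 2 to compound 3 (0.61 log units; beyond the scatter) in this assay, so growth at this nitrogen does not continue the trend set by the change from cyano to aminomethyl. Compared with the original cyano group, the longer arm gives a 1.5-fold lower number from compound 1 to compound 3 (0.18 log units; within the scatter), which means that compound 3 and compound 1 cannot be told apart on this read-out, even though the arm is much larger. Nothing available explains why the number falls at this nitrogen.

The compounds shown leave open whether the lower number goes with the new carbonyl or with the terminal amine, a question that an acetyl group on the same nitrogen could address. They also leave open how a longer chain between that carbonyl and the terminal amine would behave.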